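The source may hold more compounds than are shown below. What is called first, only, known or untested is meant among the compounds shown, and "the series" means these compounds.

Measured compounds in an assay on HEK293 cells for displacement of a labelled ligand from NPC1-like intracellular cholesterol transporter 1 (Homo sapiens); a higher number here means a weaker inhibitor, a lower number a stronger inhibitor:
compound 1 `CC(C)(C)OC(=O)NCCNC(=O)CN1CN(c2ccccc2)C2(CCN(C(=O)c3ccc(C(C)(C)C)cc3)CC2)C1=O` gives 10900 nM;
compound 2 `CCC1CCCN(C(=O)CN2CN(c3ccccc3)C3(CCN(C(=O)c4ccc(C(C)(C)C)cc4)CC3)C2=O)C1` gives 3900 nM;
compound 3 `CC1(C)CC(OC(=O)CN2CN(c3ccccc3)C3(CCN(C(=O)c4ccc(C(C)(C)C)cc4)CC3)C2=O)CC(C)(C)N1` gives 1300 nM.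

Compound 3 has the lowest of the three numbers in this assay, with compound 2 nearest (a 3.0-fold lower number from compound 2 to compound 3 (0.48 log units; beyond the scatter)) and compound 1 furthest (an 8.4-fold lower number from compound 1 to compound 3 (0.92 log units; beyond the scatter)). Compound 4 `CC(C)(C)c1ccc(C(=O)N2CCC3(CC2)C(=O)N(CC(=O)N2CCCC(O)C2)CN3c2ccccc2)cc1` differs from compound 3 only in that (3-hydroxypiperidin-1-yl in place of (2,2,6,6-tetramethylpiperidin-4-yl)oxy on a carbonyl carbon). All three measured steps vary this same carbonyl carbon and all were modest; the most telling is the step of a 3.0-fold lower number from compound 2 to compound 3 (0.48 log units; beyond the scatter), since compound 2 also carries a six-membered ring joined through its nitrogen. Compound 4 is therefore expected to give a modestly higher number than compound 3, roughly a 2.7-fold higher number from compound 3 to compound 4 (0.43 log units; beyond the scatter). The estimate for compound 4 in this assay is 3500 nM, with a range of 1200 nM to 10000 nM.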

Compound 4, half-maximal inhibitory concentration: 12200 nM
For compound 4 the middle estimate is 3.5-fold (0.54 log units) below the measured one; measured number above the stated range.
By their numbers in this assay, from the lowest: compound 3; then compound 2; then compounds 1 and 4 (each within the scatter of the next).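

At this carbonyl carbon, 3-hydroxypiperidin-1-yl in place of (2,2,6,6-tetramethylpiperidin-4-yl)oxy gives a 9.4-fold higher number from compound 3 to compound 4 (0.97 log units; beyond the scatter) in this assay, and hydroxy in place of ethyl on the saturated ring carbon gives a 3.1-fold higher number from compound 2 to compound 4 (0.50 log units; beyond the scatter), so a ring joined through its nitrogen does not by itself hold the number low. With 3-hydroxypiperidin-1-yl in place of (2-((tert-butoxycarbonyl)amino)ethyl)amino, the result is a 1.1-fold higher number from compound 1 to compound 4 (0.05 log units; within the scatter), which places a ring and an open chain level here. No measurement shown here explains these differences. The compounds shown leave open whether the oxygen link or the tetramethylpiperidine ring accounts for the lowest number. They also leave open how a methoxy group or an amine would read on the saturated ring carbon that carries the hydroxy.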